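This account rests on a few compounds, and the source may have more. Where it says the series, first, only, none or still open, it means among the compounds named here.

Going by the values given here, compound 1 `COc1ccccc1N1CCN(CC(C)(C)Nc2nc(C(F)(F)F)nc3ccccc23)CC1` and compound 2 `Cc1csc2c(N[C@@H](C)CN3CCN(S(=O)(=O)c4cccc(Cl)c4)CC3)ncnc12` are the two compounds measured so far.

In a functional assay on RH7777 cells for antagonist activity at lysophosphatidic acid receptor 2 (Homo sapiens), read by calcium flux (on this read-out higher numbers stand for weaker inhibition and lower numbers for stronger inhibition), compound 1 gives > 30000 nM, which is a limit of the assay rather than a number. Compound 2 gives 35 nM in this assay. Among the compounds with values here, that makes compound 2 the only compound with a numeric value here; the other entry is the limit of > 30000 nM in this assay, at which 1 of the 2 values shown sits. Compound 3 `Cc1ccc(S(=O)(=O)N2CCN(C[C@H](C)Nc3ncnc4c(C)csc34)CC2)cc1` has not yet been measured. It differs from compound 2 in one place (4-methylphenyl in place of 3-chlorophenyl on a sulfonyl sulfur). Within the data shown here, no measured pair shows this kind of change, so the expectation rests on compound 2 alone. The step of a 1.7-fold higher number from compound 2 to compound 3 (0.23 log units; within the scatter) is expected to be small, most likely within the usual scatter of repeated measurements, with no direction that the compounds shown can support. For compound 3 the expected value in this assay is 60 nM, with a range from 20 nM to 250 nM.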

Compound 3, half-maximal inhibitory concentration: 170 nM
For compound 3 the middle estimate is 2.8-fold (0.45 log units) below the measured one, within the range that was stated.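

Going by these compounds alone, this is the first measured pair that differs in only one place, and swapping 3-chlorophenyl for 4-methylphenyl on a sulfonyl sulfur gives a 4.9-fold higher number from compound 2 to compound 3 (0.69 log units; beyond the scatter). In this assay this means weaker inhibition, even though the two groups match in heavy-atom count and in their single six-membered aromatic ring of carbon, so the position responds to a change that leaves those counts alike. Nothing measured here accounts for the step.

This one pair changes both the kind of substituent on the ring and where it sits, so it cannot show which of the two carries the step. Going by these compounds, how the position would respond to a plain phenyl, or to a non-aromatic group such as cyclohexyl, also stays open.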